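This account rests on a few compounds, and the source may have more. Where it says the series, first, only, none or still open, it means among the compounds named here.

For the measured compounds named here, compound 2 `CCNC(=O)C1=C(C)NC(=O)NC1c1ccsc1` gives 1% in an assay on membranes from HeLa cells for displacement of a labelled ligand from adenosine receptor A3 (Homo sapiens), read by scintillation counting, with a stated time of 180 min, tested at 1 uM (on this read-out lower numbers stand for less inhibition and higher numbers for more inhibition at the one concentration tested (going by the name of the read-out)), the lower of the two numbers measured so far, while compound 1 `CCNC(=O)C1=C(C)NC(=O)NC1c1cccs1` gives 4%; the step of a number 3 percentage points lower from compound 1 to compound 2 (within the scatter) lies within the scatter. Compound 3 `CC1=C(C(=O)SC(C)C)C(c2ccsc2)NC(=O)N1` differs from compound 2 at the carbonyl carbon: isopropylsulfanyl in place of ethylamino on a carbonyl carbon. Going by the values given here, no measured step touches that carbonyl carbon; the only step known, thiophen-3-yl in place of thiophen-2-yl, was small. With both measured numbers near the floor of the scale, compound 3 is expected to stay there, an estimated step of a number 2 percentage points higher from compound 2 to compound 3 (within the scatter). Compound 3 is therefore estimated at 3%, between -8% and 15%.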

Compound 3, a percentage reported as inhibition, at one concentration (the size of the read-out at that concentration, not a potency): 1%
Estimate against measurement, compound 3: 2 percentage points above, and the stated range covers the measured number.
By their numbers in this assay, from the lowest: compounds 2, 3 and 1 (each within the scatter of the next).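

In this assay, for the compounds shown here, isopropylsulfanyl in place of ethylamino on the carbonyl carbon gives no change at the digits printed from compound 2 to compound 3 (within the scatter), the first reading at this position. Ethylamino carries a hydrogen-bond donor and isopropylsulfanyl does not, yet both compounds stay near the bottom of the scale, so this pair does not show whether the position matters. No measurement at hand bears on this result. As far as these compounds go, whether a carboxylic acid, a benzylamine or a longer chain on this carbonyl carbon would raise the number remains open.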